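A few compounds are considered here, and "the series" means these few. Any claim that something is new, unique, unknown or untested is made for them only; others in the source may bear on it.

Measured so far in a toxicity assay on NIH3T3 cells (Mus musculus) for cytotoxicity, read by resazurin assay; a lower number here means that less compound is needed, a higher number that more compound is needed for the effect:
- Compound 1 `CNC(=O)c1ccc(NCc2cncn2Cc2ccc(-c3ccccc3)cc2N)cc1-c1ccccc1`: > 1000 nM
- Compound 2 `N#Cc1ccc(NCc2cncn2Cc2ccc(-c3ccccc3)cc2)cc1-c1ccccc1`: > 1000 nM

Neither result is a number. From the compounds shown here alone, compound 2 gives > 1000 nM in this assay, and this is a limit of the assay, so its true position is unknown. Compound 1 gives > 1000 nM, which is likewise a limit. Together they show (the limit of > 1000 nM in this assay, at which 2 of the 2 values shown sit).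

Compound 3 `N#Cc1ccc(NCc2cncn2Cc2ccc(-c3ccccc3)cc2N)cc1-c1ccccc1` is made from compound 2 by one change, amino in place of hydrogen on an aromatic carbon, ortho to a large group and meta to a phenyl group. Among the compounds with values here, no measured step shows what this change does here. The expectation rests only on compound 1 remaining at the limit of > 1000 nM. The estimated change is a step that the limit leaves unreadable from compound 2 to compound 3, and it is expected to stay within the scatter, with no firm direction. Compound 3 is expected at 1500 nM, with an estimated range from 1000 nM to 8000 nM, and it will most likely be reported as a limit again.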

Compound 3, half-maximal effective concentration: > 1000 nM
Compound 3 gave a limit, no number; the forecaster's own chance of this, stated with the estimate: 85%; the middle value does not contradict the limit.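

Within the data shown here, compound 3 also gives a limit and not a number in this assay, so no step from compound 1 or compound 2 to compound 3 can be read: the limit of > 1000 nM in this assay, at which 3 of the 3 values shown sit.

The compounds shown leave open where the true values of all three lie, and whether either change alters them.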